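A Phenoxy Step Repeated on a Fluorinated Core

The source may report more compounds than this note shows. Statements on the series, on what has been measured and on what is new or still open speak of the compounds shown alone.

Compound 1 `Nc1nc(NCc2ccccc2)nc(-c2ccccc2CO)n1` was examined in a functional assay on cells for positive allosteric modulation of G-protein coupled receptor 68 (Homo sapiens), read by a luciferase reporter and cAMP accumulation, with a stated time of 30 min, at pH 6.8 and pH 8.3, in the presence of a further agent that is not named here (on this read-out higher numbers stand for higher potency (the scale is a negative logarithm) and lower numbers for lower potency), where compound 1 gives 4.35. Compound 2 `Nc1nc(NCc2ccc(Oc3ccccc3)cc2)nc(-c2ccccc2CO)n1` differs from it by one change, (phenoxy in place of hydrogen on an aromatic carbon). In this assay compound 2 gives 5.19, and the step of a number 0.84 log units higher from compound 1 to compound 2 (beyond the scatter) describes the move between the two.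

Compound 3 `Nc1nc(NCCCc2ccccc2)nc(-c2c(F)cccc2CO)n1` rests on a different core; the difference between the core of compound 1 and the core of compound 3 is not broken down here. In this assay compound 3 gives 4.47. This number and the number for compound 1 lie within the usual scatter of one another, whereas the number for compound 2 stands beyond the scatter above both.

Compound 4 `Nc1nc(NCCCc2ccc(Oc3ccccc3)cc2)nc(-c2c(F)cccc2CO)n1` has not yet been measured. It stands to compound 3 as compound 2 stands to compound 1: the change is phenoxy in place of hydrogen on an aromatic carbon, at a place described in the same words for both pairs, so it is the same change made on the second core.

Among the measured compounds shown here, because the single measured instance of this change gave a number 0.84 log units higher from compound 1 to compound 2 (beyond the scatter), the step on the second core is expected to be a number 0.78 log units higher from compound 3 to compound 4 (beyond the scatter). That expectation rests on one pair alone, and on the similar starting points of compound 1 and compound 3. Compound 4 is therefore estimated to give 5.25 in this assay, with a likely span from 4.75 to 5.75.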

Compound 4, negative logarithm of the antagonist equilibrium constant: 4.94
Beside the measured number, compound 4's estimate is 0.31 log units above it; measured number inside the range.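

On the second core, phenoxy in place of hydrogen on an aromatic carbon, para to a large group, again gave a higher number in this assay, with a number 0.47 log units higher from compound 3 to compound 4 (beyond the scatter). Set beside the first instance, the two steps point the same way and their sizes cannot be told apart: the same change on two cores in this assay, a number 0.84 log units higher (beyond the scatter) from compound 1 to compound 2 and a number 0.47 log units higher (beyond the scatter) from compound 3 to compound 4, 0.37 log units apart, within the scatter of two such steps. Among the compounds shown here, this shows that the change carried over between these two cores in direction and, within the scatter, in size, but with only two pairs it does not show that the step would hold on any other core, nor does the gap between the steps show a real loss on the second core.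

The two cores differ from each other in more than one place, so the compounds shown leave open how the fluorine and the longer chain in compounds 3 and 4 each bear on the size of the step. They also leave open whether a smaller group such as methoxy, a larger one such as benzyloxy, or a group of another kind such as an amine or a carboxylic acid, placed on the same aromatic carbon, would give a step like that of phenoxy.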